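Swapping an imidazole amide for a carbamoylmethyl amine

The compounds below may be only part of what the source reports. "The series", "measured", "known", "first", "only" and "open" are said of these compounds alone.

Three measured compounds share one core. In an assay on isolated protein for displacement of a labelled ligand from 5-hydroxytryptamine receptor 6 (Homo sapiens) (a higher number here means a weaker inhibitor, a lower number a stronger inhibitor), compound 1 `CN(C[C@@H]1CCCc2cc(S(=O)(=O)c3cccc(F)c3)ccc21)S(N)(=O)=O` gives 3.98 nM and compound 2 `CN(C)S(=O)(=O)NC[C@@H]1CCCc2cc(S(=O)(=O)c3cccc(F)c3)ccc21` gives 2 nM. Compound 3 `O=C(NC[C@@H]1CCCc2cc(S(=O)(=O)c3cccc(F)c3)ccc21)c1ncc[nH]1` gives 15.9 nM in this assay, the highest of the three numbers: a 4.0-fold higher number from compound 1 to compound 3 (0.60 log units; beyond the scatter), and an 8.0-fold higher number from compound 2 to compound 3 (0.90 log units; beyond the scatter). Compound 4 `CN(CC(N)=O)C[C@@H]1CCCc2cc(S(=O)(=O)c3cccc(F)c3)ccc21` carries (carbamoylmethyl)(methyl)amino in place of ((1H-imidazol-2-yl)carbonyl)amino on a saturated chain carbon bound to a saturated ring carbon. Among the compounds with values here, no measured step exchanges this exact pair of groups, so the expectation is indirect: both steps into compound 3 show that the (1H-imidazol-2-yl)carbonyl group comes with higher numbers than either sulfamoyl group. Removing that group is therefore expected to lower the number for compound 4 by a modest step of a 2.0-fold lower number from compound 3 to compound 4 (0.30 log units; within the scatter). Compound 4 is estimated at 8 nM, with a range from 2.5 nM to 25 nM.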

Compound 4, inhibition constant: 1.26 nM
Estimate against measurement, compound 4: 6.3-fold (0.80 log units) above; the whole stated range lies above it.
By their numbers in this assay, from the lowest: compounds 4, 2 and 1 (each within the scatter of the next, the first and the last beyond it); then compound 3.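

The step into compound 4 shows that this place, on a saturated chain carbon bound to a saturated ring carbon, tolerates a group with no sulfamoyl unit and no ring (a 13-fold lower number from compound 3 to compound 4 (1.10 log units; beyond the scatter)). In this assay, the (carbamoylmethyl)(methyl)amino group stands level with the dimethylsulfamoyl group (a 1.6-fold lower number from compound 2 to compound 4 (0.20 log units; within the scatter)) and goes beyond the methyl(sulfamoyl)amino group (a 3.2-fold lower number from compound 1 to compound 4 (0.50 log units; beyond the scatter)). No measurement here explains these steps. Still open, going by these compounds, is whether a carboxylic acid or a longer chain in place of the carbamoylmethyl group would keep these low numbers.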